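The source may hold more compounds than are shown below. What is called first, only, known or untested is meant among the compounds shown, and "the series" means these compounds.

Measured in a physicochemical assay for lipophilicity; on this read-out lower numbers stand for lower lipophilicity and higher numbers for higher lipophilicity:
- compound 1 `O=C(Nc1ccc(Cl)cc1)Nc1ccc2c(c1)C(Nc1ccc(Cl)cc1Cl)=NS2(=O)=O`, 4.24
- compound 2 `O=C(Nc1ccc(OC2=NS(=O)(=O)c3ccccc32)cc1)Nc1ccccc1Cl`, 3.55

Compound 1 holds the higher of the two numbers; compound 2 sits lower, and that gap lies beyond the usual scatter of this assay. Going by the values given here, no single-point steps between measured compounds exist in this set.

Compound 3 `O=C(Nc1ccccc1)Nc1ccc2c(c1)C(Nc1ccc(Cl)cc1Cl)=NS2(=O)=O` differs from compound 1 by hydrogen in place of chloro on an aromatic carbon. For this step in this assay a downward move beyond the scatter is expected. Compound 3 is therefore estimated at 3.55, range 3.2 to 3.9, an expected step of a number 0.69 log units lower from compound 1 to compound 3 (beyond the scatter).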

Compound 3, partition coefficient: 3.57
For compound 3 the middle estimate is 0.02 log units below the measured one; low and high end bracket the measured number.
By their numbers in this assay, from the lowest: compounds 2 and 3 (each within the scatter of the next); then compound 1.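

In this assay, going by these compounds alone, the change from 4-chlorophenyl to phenyl gives a number 0.67 log units lower from compound 1 to compound 3 (beyond the scatter) and provides the first single-point step. The position para to a large group is therefore not silent on this read-out, and with the rest of compound 1 unchanged, the step belongs to this one chlorine. No measured evidence on the origin of the step is at hand.

As far as these compounds go, whether a fluoro, methoxy or carboxylic acid at this place would move the number likewise remains open. A single pair also cannot show whether the step carries over to another core.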